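This account rests on a few compounds, and the source may have more. Where it says the series, first, only, none or still open, it means among the compounds named here.

Measured in an ADME assay on J774 cells (Mus musculus) for cytotoxicity, with a stated time of 72 h; a lower number here means that less compound is needed, a higher number that more compound is needed for the effect:
- compound 1 `COC(=O)c1c[nH]c2cc(N3CCN(c4ccccc4)CC3)ccc2c1=O`: > 20000 nM
- compound 2 `COC(=O)c1c[nH]c2cc(N3CCN(c4ccccc4)CC3)c(C)cc2c1=O`: 17000 nM
- compound 3 `COC(=O)c1c[nH]c2cc(N3CCN(c4ccccc4)CC3)c(OC)cc2c1=O`: 17000 nM

Compound 1 gives > 20000 nM, and this is a limit of the assay, not a number.

Compound 4 `COC(=O)c1c[nH]c2cc(N3CCN(c4ccc(OC)cc4)CC3)ccc2c1=O` keeps the core of compound 1 but has methoxy in place of hydrogen on an aromatic carbon, so that phenyl becomes 4-methoxyphenyl: methoxy in place of hydrogen on an aromatic carbon.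

The closest measured precedent is the same kind of swap at a different place in the molecule, which gives an at least 1.1-fold lower number from compound 1 to compound 3 (0.07 log units; that floor lies within the scatter). The methyl swap gives an at least 1.1-fold lower number from compound 1 to compound 2 (0.07 log units; that floor lies within the scatter). Exchanging one of these groups for the other gives no change at the digits printed from compound 2 to compound 3 (within the scatter). None of these steps is shown to go beyond the scatter, so no clear shift is expected in this assay, and the result for compound 4 may again be only a limit.

The expected step is an at least 1.0-fold lower number from compound 1 to compound 4 (0.02 log units; that floor lies within the scatter).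

For compound 4 the estimated value is 19000 nM, with an expected range from 11000 nM to 32000 nM.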

Compound 4, half-maximal effective concentration: > 20000 nM
Compound 4 gave a limit, no number; the forecaster's own chance of this, stated with the estimate: 55%; middle value at least 1.0-fold (0.02 log units) away from the limit.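

No step from compound 1 to compound 4 can be read in this assay, because each of the two compounds gives only a limit of the assay, not a number: the limit of > 20000 nM in this assay, at which 2 of the 4 values shown sit.

The compounds shown leave open whether 4-methoxyphenyl in place of phenyl changes the number in this assay at all, and by how much.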